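The compounds below may be only part of what the source reports. "The series", "measured", "known", "first", "only" and "open" are said of these compounds alone.

Compound 1 `Cn1c(OCC(C)(C)C(=O)Nc2ccccc2)nnc1-c1ccc(NC(=O)c2ccc3ccccc3c2)cc1` is one of two compounds tested in an assay on 3T3-L1 cells for inhibition of diacylglycerol O-acyltransferase 1 (Mus musculus); a higher number here means a weaker inhibitor, a lower number a stronger inhibitor. In this assay compound 1 gives 220 nM, the only plain number among the two results shown. Compound 2 `CCC(Sc1nnc(-c2ccc(NC(=O)c3ccc(Cl)c(Cl)c3)cc2)n1C)C(=O)O` is a different matter. In this assay compound 2 reads > 20000 nM, which is a limit of the assay rather than a number; this is summed up as the limit of > 20000 nM in this assay, at which 1 of the 2 values shown sits. Compound 1 therefore stands alone as the one measured anchor.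

Compound 3 `Cn1c(OCC(C)(C)C(N)=O)nnc1-c1ccc(NC(=O)c2ccc3ccccc3c2)cc1` has not yet been measured. It differs from compound 1 in a single place: hydrogen in place of phenyl on an amide-type nitrogen, that is, anilino becomes amino and the phenylcarbamoyl group becomes carbamoyl. For the measured compounds named here, no measured pair here shows this particular change, so its effect is open. The step of a 3.2-fold higher number from compound 1 to compound 3 (0.50 log units; beyond the scatter) is expected to be a moderate weakening, somewhat beyond the usual scatter. Compound 3 is thus estimated at 700 nM, with a likely range from 200 nM to 3000 nM.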

Compound 3, half-maximal inhibitory concentration: 6100 nM
Compound 3: the middle estimate sits 8.7-fold (0.94 log units) below what was measured; measured number above the stated range.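

Replacing the phenyl on the amide-type nitrogen with hydrogen gives a 28-fold higher number from compound 1 to compound 3 (1.44 log units; beyond the scatter) in this assay. For the compounds shown here, this is the first comparison here in which only one place changes, and it shows that this position is sensitive: the phenyl of compound 1 counts for much of its strength as an inhibitor, and the plain carbamoyl end of compound 3 gives a much weaker one. Nothing measured here explains why the step is so large.

On these data alone, what remains open is how much of the phenyl is needed on that nitrogen, since a methyl, a cyclohexyl ring or a benzyl group could tell whether any carbon group restores the strength or only an aromatic ring does. How a chlorine or methoxy group on the phenyl itself would shift the value is also unknown.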